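Swapping Trifluoromethyl for Methoxy on a Cyclic Amine

A few compounds are considered here, and "the series" means these few. Any claim that something is new, unique, unknown or untested is made for them only; others in the source may bear on it.

Compound 1 `CC(C)(C)C1CNCCNCCNCCN1` and compound 2 `FC(F)(F)c1ccc(C2CNCCNCCNCCN2)cc1` were tested in an ADME assay on HEK293 cells (Homo sapiens) for cytotoxicity; a lower number here means that less compound is needed, a higher number that more compound is needed for the effect. In this assay compound 1 gives > 200000 nM, which is a limit of the assay rather than a number. Among the measured compounds shown here, compound 2 gives 73000 nM in this assay, the only actual number available. The remaining value, that of compound 1, sits at the limit of > 200000 nM in this assay, at which 1 of the 2 values shown sits. Compound 3 `COc1ccc(C2CNCCNCCNCCN2)cc1` carries methoxy in place of trifluoromethyl on an aromatic carbon. For the measured compounds named here, no measured pair shows what this swap does, so the expected step is a 1.6-fold higher number from compound 2 to compound 3 (0.22 log units; within the scatter), modest in size. Compound 3 is therefore estimated at 120000 nM, between 40000 nM and 400000 nM.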

Compound 3, half-maximal effective concentration: > 200000 nM
Compound 3 was reported as a limit (the forecaster's own chance of this, stated with the estimate: 35%); at least 1.6-fold (0.22 log units) between middle value and limit.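

The pair of compound 2 and compound 3 shows that this one place matters: on an aromatic carbon para to a large group, methoxy in place of trifluoromethyl gives an at least 2.7-fold higher number from compound 2 to compound 3 (0.43 log units; beyond the scatter) in this assay. This single change on the shared core takes the compound from a measured number to the limit of the assay. The value of compound 3 is a limit and not a number, so the true size of the step stays unknown: the limit of > 200000 nM in this assay, at which 2 of the 3 values shown sit.

The compounds shown leave open what a chlorine atom, an amine or a carboxylic acid on this same carbon would give. They also leave open how far beyond the limit compound 3 lies.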